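A few compounds are considered here, and "the series" means these few. Any claim that something is new, unique, unknown or untested is made for them only; others in the source may bear on it.

In an assay on isolated protein (Mus musculus) for inhibition of IL15-IL15 receptor (Homo sapiens), read by resazurin assay, with stated times of 30 min and 2.5 days (a higher number here means a weaker inhibitor, a lower number a stronger inhibitor), two compounds that share one core have been tested. Compound 1 `Cn1c(Cc2nn(C)c(=O)c3ccccc23)nnc1SCC(=O)Nc1ccc(F)cc1F` is reported as "not active" (no number reported), with no number attached. Within the data shown here, compound 2 `CCCCCCCCCCSc1nnc(Cc2nn(C)c(=O)c3ccccc23)n1C` gives 7600 nM, and this is the only numerical result in this assay so far, so no measured step between neighbouring compounds is available to lean on. Compound 3 `Cn1c(Cc2nn(C)c(=O)c3ccccc23)nnc1SCC(=O)Nc1ccc(I)cc1` has not yet been measured. It differs from compound 2 by (4-iodophenyl)carbamoyl in place of nonyl on a saturated chain carbon bound to a sulfur. Compound 1 carries a closely related carbamoyl group on the same carbon bound to sulfur, and compound 1 produced no measurable inhibition at all. On that basis the move from the nonyl chain to the carbamoyl group is expected to weaken inhibition rather than strengthen it, by a step larger than the usual scatter, and there is a real chance that compound 3, like compound 1, returns no number in this assay. The step that this estimate means is expected to be a 2.4-fold higher number from compound 2 to compound 3 (0.37 log units; beyond the scatter). For compound 3 the estimate is 18000 nM, with a range from 5000 nM to 70000 nM.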

Compound 3, half-maximal inhibitory concentration: "not active" (no number reported)
Compound 3: no number reported; no gap can be computed for the estimate.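

In this assay, among these compounds, compound 3, like compound 1, gives no number, so no step from compound 2 to compound 3 can be read. The compounds shown leave open whether the nonyl chain of compound 2 is what allows measurable inhibition, or how far other groups in that place would. No measured evidence here explains the result.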